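The source may report more compounds than this note shows. Statements on the series, on what has been measured and on what is new or still open speak of the compounds shown alone.

Measured compounds:
compound 1 `O=S(=O)(c1cccc(F)c1)c1cnc2cc(Cl)ccc2c1N1CCC(CO)CC1` — 71%
compound 2 `CC1CCN(c2c(S(=O)(=O)c3cc(Cl)cc(Cl)c3)cnc3cc(Cl)ccc23)CC1` — 93%
compound 3 `COc1ccc2ncc(S(=O)(=O)c3ccc(OC)c(OC)c3)c(N3CCC(C)CC3)c2c1` — -3%

In an assay on isolated protein for displacement of a labelled ligand from metabotropic glutamate receptor 5 (Homo sapiens), with a stated time of 60 min, tested at 1 uM (on this read-out higher numbers stand for more inhibition at the one concentration tested (going by the name of the read-out) and lower numbers for less inhibition), compound 3 stands lowest of the three numbers, far below compound 1 and compound 2, both gaps beyond the scatter. Compound 4 `COc1cccc(S(=O)(=O)c2cnc3ccc(OC)cc3c2N2CCC(C)CC2)c1` is not yet measured. Compared with compound 3, the change is hydrogen in place of methoxy on an aromatic carbon. Among the measured compounds shown here, no two measured compounds differ in only one place, so no measured step can guide this change directly. Compound 1 and compound 2 show that high inhibition is possible in this series, but they differ from compound 3 in several places at once. For compound 4 a small rise is expected, likely not beyond the scatter, a step of a number 15 percentage points higher from compound 3 to compound 4 (beyond the scatter). The value of compound 4 is estimated at 12%, in the range -10% to 45%.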

Compound 4, a percentage reported as inhibition, at one concentration (the size of the read-out at that concentration, not a potency): 0%
The estimate for compound 4 lay 12 percentage points above the measured number, and the stated range covers the measured number.
By their numbers in this assay, from the lowest: compounds 3 and 4 (each within the scatter of the next); then compound 1; then compound 2.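

Going from 3,4-dimethoxyphenyl to 3-methoxyphenyl in this assay gives a number 3 percentage points higher from compound 3 to compound 4 (within the scatter) and forms the first measured pair here that differs in only one place. At this position, hydrogen in place of methoxy brings no clear gain in inhibition, so this single methoxy does not decide the read-out in this pair. Nothing measured here speaks to the reason for this result.

As far as these compounds go, it remains open whether an amine or a carboxylic acid at this place would shift the number. From the compounds shown here alone, it is also open whether the same change would read alike on a compound with clear inhibition.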